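The source may hold more compounds than are shown below. What is called first, only, known or untested is meant among the compounds shown, and "the series" means these compounds.

Working notes on the series. Compound 1 `C=CCn1c(=O)/c(=C\c2cccc(F)c2)[nH]c(=O)/c1=C\c1ccccc1OC` is the reference point: in a functional assay on NCI-H1975 cells (Homo sapiens) for cytotoxicity, read by CCK-8 assay, with a stated time of 72 h (on this read-out lower numbers stand for stronger inhibition and higher numbers for weaker inhibition), compound 1 gives 25600 nM, and this is the only entry for which a number is reported at all. Two further members of the series return no number. Compound 2 `C=CCn1c(=O)/c(=C\c2ccc(C)cc2)[nH]c(=O)/c1=C\c1ccccc1OC` is reported in this assay as "not active" (no number reported). Compound 3 `C=CCn1c(=O)/c(=C\c2cccc(Br)c2)[nH]c(=O)/c1=C\c1cccc(Br)c1` is likewise reported in this assay as "not active" (no number reported). No two of these compounds differ in a single place, so no step between measured values can be stated; the picture is simply one weak number beside two entries with no number.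

Compound 4 `C=CCn1c(=O)/c(=C\c2cccc(C)c2)[nH]c(=O)/c1=C\c1ccccc1OC` is the next candidate. Relative to compound 1 it carries the change (methyl in place of fluoro on an aromatic carbon), placed on an aromatic carbon of a six-membered aromatic ring of carbon only, meta to a large group. Among the measured compounds shown here, a methyl on the same ring is present in compound 2, which carries no number in this assay, although the position there is not the same and no step to compound 1 is on record.

Given that compound 1 already sits at 25600 nM and that methyl in place of fluoro has no measured counterpart here, the expectation for a 1.8-fold higher number from compound 1 to compound 4 (0.24 log units; within the scatter) is a step toward weaker inhibition, modest in size and possibly inside the scatter. Compound 4 is therefore estimated at 45000 nM, within 20000 nM to 100000 nM, with a real chance that only a limit is reported.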

Compound 4, half-maximal inhibitory concentration: 32800 nM
Estimate against measurement, compound 4: 1.4-fold (0.14 log units) above; the measured number falls inside the stated range.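

In this assay, among the compounds shown here, the exchange of 3-fluorophenyl for 3-methylphenyl gives a 1.3-fold higher number from compound 1 to compound 4 (0.11 log units; within the scatter), the first step on record, so at this place fluoro and methyl cannot be told apart by this read-out. The methyl group is thus not incompatible with a measurable number: compound 4 gives 32800 nM, whereas compound 2, with its methyl at another place on the same ring, is reported as "not active". No independent data on these compounds bear on this result, so the contrast between compound 4 and compound 2 remains an observation without an explanation.

Going by these compounds, both substituents at this place are single-atom groups, and the numbers remain in the same weak range, so it stays open whether a different group here, such as an amine or a carboxylic acid, would give a step beyond the scatter. On these data alone, it is equally open whether this tolerance holds with a longer chain in place of the allyl group on the shared core, or with a group other than methoxy on the second aromatic ring.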